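The source may report more compounds than this note shows. Statements on the series, on what has been measured and on what is new or still open speak of the compounds shown alone.

The shared core of compound 1 `O=C(O)CSc1ccc(NCc2cccc(Oc3ccccc3)c2)cc1` carries the varying group on an aromatic carbon, and in a functional assay on CHO cells for agonist activity at Free fatty acid receptor 1 (Homo sapiens), read by a luciferase reporter (on this read-out lower numbers stand for smaller maximal responses and higher numbers for larger maximal responses), compound 1 gives 84%. Compound 2 `O=C(O)[C@H]1C[C@@H]1c1ccc(NCc2cccc(Oc3ccccc3)c2)cc1` bears a 2-carboxycyclopropyl group; in this assay compound 2 gives 88%; 72% (2 entries), with the spread of its repeats shown by the several entries of compound 2 in this assay, 88%; 72% (2 entries). Compound 3 `CC(Cc1ccc(NCc2cccc(Oc3ccccc3)c2)cc1)C(=O)O` carries a 2-carboxypropyl group, and in this assay compound 3 gives 70%, the lower of the two single numbers, the gap between the two being a number 14 percentage points lower from compound 1 to compound 3 (beyond the scatter). Compound 4 `O=C(O)[C@@H]1C[C@H]1c1ccc(NCc2cccc(Oc3ccccc3)c2)cc1` differs from compound 3 by 2-carboxycyclopropyl in place of 2-carboxypropyl on an aromatic carbon, the two stereocentres set the other way round from compound 2, whose two entries are the nearest guide. The step is therefore expected to be a number 8 percentage points higher from compound 3 to compound 4 (within the scatter), upward. Compound 4 is expected to give 78% in this assay, between 60% and 92%.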

Compound 4, largest response reached (reported as percent of maximum), in percent of the reference or control that the assay uses: 64%
Compound 4: the middle estimate sits 14 percentage points above what was measured; low and high end bracket the measured number.
By their numbers in this assay, from the lowest: compounds 4 and 3 (each within the scatter of the next); then compound 1.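

In this assay, closing the three-membered ring gives a number 6 percentage points lower from compound 3 to compound 4 (within the scatter), so in this configuration the ring does not move the response away from that of the open 2-carboxypropyl group. Set against the (carboxymethyl)sulfanyl group, the same ring gives a number 20 percentage points lower from compound 1 to compound 4 (beyond the scatter), a second replacement at this aromatic carbon to fall beyond the scatter. Among the compounds shown here, compound 4 gives 64% and compound 2 gives 88%; 72% (2 entries), which is the first view of the configuration at this position: the fact that compounds 2 and 4 differ only in the configuration as drawn.

How much the configuration counts stays unsettled, given the repeats: the several entries of compound 2 in this assay, 88%; 72% (2 entries). Also open, going by these compounds, is how a carboxamide in place of the carboxylic acid would read in this assay.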